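This account rests on a few compounds, and the source may have more. Where it says the series, first, only, none or still open, it means among the compounds named here.

Measured compounds:
compound 1, `CCOC(=O)N1CCC(Oc2ncnc(Oc3ccc(/C=C4\SC(=O)NC4=O)cc3)c2C)CC1`, 141%
compound 2, `Cc1c(Oc2ccc(/C=C3\SC(=O)NC3=O)cc2)ncnc1OC1CCN(C(=O)OCC(C)C)CC1`, 70.2%
compound 3, `Cc1c(Oc2ccc(/C=C3\SC(=O)NC3=O)cc2)ncnc1OC1CCN(C(=O)OCc2ccccc2)CC1`, 43.3%

In a functional assay on CHO-K1 cells for agonist activity at Glucose-dependent insulinotropic receptor (Homo sapiens), read by cAMP accumulation and immunoassay, with a stated time of 1 h (on this read-out higher numbers stand for larger maximal responses and lower numbers for smaller maximal responses), compound 2 stands second highest of the three: compound 3 lies a number 26.9 percentage points lower from compound 2 to compound 3 (beyond the scatter) below it, and compound 1 lies a number 70.8 percentage points lower from compound 1 to compound 2 (beyond the scatter) above it. Compound 4, `CC(C)COC(=O)N1CCC(Oc2cc(Oc3ccc(/C=C4\SC(=O)NC4=O)cc3)ncn2)CC1`, is not yet measured. It differs from compound 2 by hydrogen in place of methyl on an aromatic carbon. Within the data shown here, every measured step concerns the group on the saturated chain carbon bound to an oxygen next to a carbonyl group, from methyl to isopropyl or phenyl; none touches the aromatic methyl, so no measured step bears on this change. Without such a guide, no step beyond the scatter is expected for compound 4, with a wide range: 70%, from 40% to 110%, a step of a number 0.2 percentage points lower from compound 2 to compound 4 (within the scatter) that is expected rather than known.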

Compound 4, largest response reached (Emax), in percent of the reference or control that the assay uses: 51%
Estimate against measurement, compound 4: 19 percentage points above; measured number inside the range.
By their numbers in this assay, from the lowest: compounds 3 and 4 (each within the scatter of the next); then compound 2; then compound 1.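

In this assay, the aromatic methyl proves to matter: hydrogen in its place gives a number 19.2 percentage points lower from compound 2 to compound 4 (beyond the scatter). The earlier compounds shown here all carried this methyl, so they could say nothing about this position on the ring with two nitrogens. Nothing measured here explains why the response changes at this position.

From the compounds shown here alone, whether an ethyl group, a chlorine atom or a methoxy group on this aromatic carbon would give a larger or smaller response remains open. So does whether hydrogen in place of methyl would give a similar step in compound 1 or compound 3.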